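The source may hold more compounds than are shown below. What is called first, only, known or untested is meant among the compounds shown, and "the series" means these compounds.

Within the data shown here, in a functional assay on HEK293 cells for agonist activity at probable G-protein coupled receptor 27 (Homo sapiens), read by a luciferase reporter and beta-arrestin recruitment, with a stated time of 10 min (on this read-out higher numbers stand for an effect only at larger amounts of compound and lower numbers for an effect already at smaller amounts), compound 2 `Cc1cc(Cl)ccc1C(=O)Nc1ccc(S(=O)(=O)Nc2ccccc2)cc1` gives 912 nM, the only numerical value in this small set. Compound 1 `COc1ccc(NS(=O)(=O)c2ccc(NC(=O)c3ccc(Cl)cc3Cl)cc2)cc1` reaches only the limit of > 100000 nM in this assay. Compound 3 `O=C(Nc1ccc(Cl)cc1Cl)c1ccc(S(=O)(=O)Nc2ccccc2)cc1` likewise stops at the limit of > 100000 nM in this assay. Compound 2 therefore stands alone with a number, beside (the limit of > 100000 nM in this assay, at which 2 of the 3 values shown sit). Compound 4 `N#Cc1ccc(C(=O)Nc2ccc(S(=O)(=O)Nc3ccccc3)cc2)c(F)c1` has not yet been measured; it differs from compound 2 by 4-cyano-2-fluorophenyl in place of 4-chloro-2-methylphenyl on a carbonyl carbon. Among the measured compounds shown here, no step between measured compounds is available to guide this change. A modest loss beyond the usual scatter is expected, a step of a 4.4-fold higher number from compound 2 to compound 4 (0.64 log units; beyond the scatter). Compound 4 is thus estimated at 4000 nM in this assay, with a range from 600 nM to 50000 nM.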

Compound 4, half-maximal effective concentration: 229 nM
Compound 4: the middle estimate sits 17-fold (1.24 log units) above what was measured; the measured number lies below the stated range.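

The carbonyl carbon's aryl position in this assay proves open to change: 4-cyano-2-fluorophenyl in place of 4-chloro-2-methylphenyl gives a 4.0-fold lower number from compound 2 to compound 4 (0.60 log units; beyond the scatter). Neither the chlorine nor the methyl is therefore needed for a measured number in this pair, and a nitrile with a fluorine serves there as well. The set now holds one readable step, while its other entries remain limits of the assay: the limit of > 100000 nM in this assay, at which 2 of the 4 values shown sit.

The nitrile and the fluorine enter together, so the step cannot be divided between them. As far as these compounds go, whether a carboxylic acid or an amine on this ring would be accepted also remains open.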